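Chain substituent variation on the shared core

The compounds below may be only part of what the source reports. "The series", "measured", "known", "first", "only" and "open" are said of these compounds alone.

Measured compounds in an assay on isolated protein for inhibition of Nitric oxide synthase, inducible (Homo sapiens), with a stated time of 30 min; on this read-out higher numbers stand for weaker inhibition and lower numbers for stronger inhibition:
compound 1 `Cc1cc(N)nc(CC(C)F)c1`: 220 nM
compound 2 `C/C=C/c1cc(C)cc(N)n1`: 282 nM

Among the measured compounds shown here, compound 1 stands at one end of the two numbers so far, with compound 2 inside the scatter of it: the only measured step, a 1.3-fold higher number from compound 1 to compound 2 (0.11 log units; within the scatter), does not separate the two. Compound 3 `Cc1cc(N)nc(CC(C)OCCF)c1` has not yet been measured in this assay. It differs from compound 1 by 2-fluoroethoxy in place of fluoro on a saturated chain carbon bound to two saturated chain carbons. For the measured compounds named here, the one measured step concerns an exchange on an aromatic carbon and is within the scatter; no measured step touches the saturated chain carbon where the change in compound 3 sits, so the series gives no direct guide to this exchange. The 2-fluoroethoxy group brings one hydrogen-bond acceptor and three more heavy atoms than the fluoro it replaces, and with nothing measured on that chain position the expectation is a small step at most, with the uncertainty wide in both directions. The expected step for compound 3 is a 1.6-fold higher number from compound 1 to compound 3 (0.20 log units; within the scatter). Compound 3 is estimated at 350 nM, with a range of 110 nM to 1200 nM.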

Compound 3, half-maximal inhibitory concentration: > 5000 nM
Compound 3 ended at the assay's limit (the forecaster's own chance of this, stated with the estimate: 5%); at least 14-fold (1.15 log units) between middle value and limit.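

In this assay, among the compounds shown here, the saturated chain carbon bound to two saturated chain carbons tolerates far less than the earlier pair could reveal: 2-fluoroethoxy in place of fluoro gives an at least 22-fold higher number from compound 1 to compound 3 (1.35 log units; beyond the scatter), whereas the only earlier step, on an aromatic carbon, was a 1.3-fold higher number from compound 1 to compound 2 (0.11 log units; within the scatter). For the compounds shown here, the result for compound 3 is a limit of the assay and not a number: the limit of > 5000 nM in this assay, at which 1 of the 3 values shown sits. The step therefore sets only a floor on the size of this change, and its true size cannot be read; even so, this chain position is the first place where a single exchange separates two compounds.

The compounds shown do not separate the ether oxygen of 2-fluoroethoxy from its added length or its terminal fluorine, and a methoxy, an ethoxy or a plain propyl chain on the same carbon would pull these apart. A hydroxyl or a plain hydrogen at that carbon would show whether the fluoro of compound 1 itself matters to the read-out, or whether the chain position simply accepts only small groups.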